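A few compounds are considered here, and "the series" means these few. Any claim that something is new, unique, unknown or untested is made for them only; others in the source may bear on it.

Working notes on the series. All four compounds share one core; compound 1 `CNc1nc(Nc2ccc(C)c([N+](=O)[O-])c2)ncc1C(=O)Nc1cc(NC(=O)c2cccc(C(F)(F)F)c2)ccc1C` carries a 3-(trifluoromethyl)phenyl on the carbonyl carbon, compound 2 `CNc1nc(Nc2ccc(C)c([N+](=O)[O-])c2)ncc1C(=O)Nc1cc(NC(=O)c2cccc(OC)c2)ccc1C` a methoxy in place of that trifluoromethyl, and compound 3 `CNc1nc(Nc2ccc(C)c([N+](=O)[O-])c2)ncc1C(=O)Nc1cc(NC(=O)c2cc(OC)cc(OC)c2)ccc1C` a 3,5-dimethoxyphenyl. In an ADME assay on BaF3 cells (Mus musculus) for antiproliferative activity, read by CellTiter-Glo and CCK-8 assay, with a stated time of 72 h (a lower number here means a stronger inhibitor of growth, a higher number a weaker inhibitor of growth), compound 2 gives 6310 nM. Compound 1 gives > 10000 nM, which is a limit of this assay and not a number. Compound 3 likewise gives > 10000 nM, again a limit and not a number. The step from compound 1 to compound 2 is an at least 1.5-fold lower number from compound 1 to compound 2 (0.19 log units; that floor lies within the scatter); the step from compound 2 to compound 3 is an at least 1.5-fold higher number from compound 2 to compound 3 (0.19 log units; that floor lies within the scatter); the step from compound 1 to compound 3 is a step that the two limits leave unreadable from compound 1 to compound 3 because both values sit at the limit of > 10000 nM in this assay, at which 2 of the 3 values shown sit. Compound 3 therefore stands at the limit, alongside compound 1, with only compound 2 giving a number.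

Compound 4 `CNc1nc(Nc2ccc(C)c([N+](=O)[O-])c2)ncc1C(=O)Nc1cc(NC(=O)c2ccc3c(c2)OCCO3)ccc1C` differs from compound 3 by 2,3-dihydro-1,4-benzodioxin-6-yl in place of 3,5-dimethoxyphenyl on a carbonyl carbon. Among the compounds with values here, the only measured step that touches this position is the one from compound 2 to compound 3, which carried the number to the limit; no measured step covers the closing of the two oxygens into a ring. Compound 4 is expected to remain near the limit, an expected step of an at least 1.1-fold lower number from compound 3 to compound 4 (0.04 log units; that floor lies within the scatter) in this assay. The estimate for compound 4 is 9000 nM, within 3000 nM to 30000 nM.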

Compound 4, concentration for 50% growth inhibition: > 10000 nM
Compound 4 was reported as a limit (the forecaster's own chance of this, stated with the estimate: 50%); at least 1.1-fold (0.04 log units) between middle value and limit.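

The ring closure gives no readable gain at this position. In this assay, within the data shown here, compound 4 gives > 10000 nM, which is a limit and not a number, so the fused 2,3-dihydro-1,4-benzodioxin-6-yl joins the 3,5-dimethoxyphenyl and the 3-(trifluoromethyl)phenyl at the limit, and the 3-methoxyphenyl of compound 2 remains the only group here with a number. The one readable step is an at least 1.5-fold higher number from compound 2 to compound 4 (0.19 log units; that floor lies within the scatter), while the steps to compound 4 from compound 1 and from compound 3 cannot be read because all three values stand at the same limit: the limit of > 10000 nM in this assay, at which 3 of the 4 values shown sit.

Open, from the compounds shown here alone, is how far compound 1, compound 3 and compound 4 lie from one another past the limit, and so whether closing the two oxygens into a ring changes anything at all. Among these compounds, also open is whether an aromatic ring on the carbonyl carbon bearing an amine or a carboxylic acid, or a longer chain in its place, would give a number clearly lower than the one compound 2 gives, 6310 nM.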